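The compounds below may be only part of what the source reports. "The series", "measured", "known", "first", "only" and "open" are said of these compounds alone.

Notes on the series. In a functional assay on RH7777 cells for antagonist activity at lysophosphatidic acid receptor 2 (Homo sapiens), read by calcium flux (a lower number here means a stronger inhibitor, a higher number a weaker inhibitor), compound 1 `Cc1ccccc1N1CCN(C[C@H](C)Nc2nc(C(F)(F)F)nc3ccccc23)CC1` gives 730 nM. Compound 2 `Cc1csc2c(N[C@@H](C)CN3CCN(S(=O)(=O)c4ccc(Cl)c(Cl)c4)CC3)ncnc12` gives 17 nM in this assay, the lowest of the two numbers measured; its gap to compound 1 lies beyond the scatter. Compound 3 `COc1ccccc1N1CCN(CC(C)(C)Nc2nc(C(F)(F)F)nc3ccccc23)CC1` reaches only a limit of the assay, > 30000 nM. Compound 4 `Cc1csc2c(N[C@@H](C)CN3CCN(S(=O)(=O)c4cccc(Cl)c4)CC3)ncnc12` has not yet been measured; it differs from compound 2 by hydrogen in place of chloro on an aromatic carbon, a hydrogen in place of chloro on an aromatic carbon. Within the data shown here, no pair differing in one place has been measured, so no step size is on record; the loss of one chloro is expected to cost a modest amount, probably more than the scatter but far short of the gap to compound 1. Compound 4 is therefore estimated at 50 nM in this assay, within 15 nM to 200 nM, the expected step being a 2.9-fold higher number from compound 2 to compound 4 (0.47 log units; beyond the scatter).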

Compound 4, half-maximal inhibitory concentration: 35 nM
Estimate against measurement, compound 4: 1.4-fold (0.15 log units) above, within the range that was stated.
By their numbers in this assay, from the lowest: compound 2; then compound 4; then compound 1. At a limit, above all of these: compound 3.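

Among these compounds, the change from 3,4-dichlorophenyl to 3-chlorophenyl gives a 2.1-fold higher number from compound 2 to compound 4 (0.31 log units; beyond the scatter) in this assay, the only one-place step so far. The chloro para to a large group therefore matters only modestly: without it, compound 4 still gives 35 nM. Nothing on record gives a cause for this step.

Open, from the compounds shown here alone, is how a fluorine, a methyl or a methoxy group at this position would compare with chloro and hydrogen. Also open, going by these compounds, is what the remaining chloro contributes, and whether it could be replaced by a nitrile.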